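The source may hold more compounds than are shown below. What is called first, only, known or untested is meant among the compounds shown, and "the series" means these compounds.

Compound 1 has the structure `COc1cc(-c2cc(/C=C/C(=O)c3ccc(Cl)c(Cl)c3)[nH]n2)cc(OC)c1OC`. In a functional assay on NCI-H322M cells (Homo sapiens) for cytotoxicity, read by sulforhodamine B assay, with a stated time of 48 h, tested at 0.01 uM (on this read-out higher numbers stand for a weaker effect at the one concentration tested and lower numbers for a stronger effect), compound 1 gives 89%. Among the measured compounds shown here, the only other compound measured in this assay is compound 2, `COc1ccc(-c2cc(/C=C/C(=O)c3ccc(N)cc3)[nH]n2)cc1OC`, and in this assay compound 2 gives 96%. These two numbers lie within the scatter of each other, so neither compound can be set apart from the other; both show a weak effect at the single concentration tested.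

Compound 3, `COc1ccc(C(=O)/C=C/c2cc(-c3cc(OC)c(OC)c(OC)c3)n[nH]2)cc1OC`, has not yet been measured. Against compound 1 the change is 3,4-dimethoxyphenyl in place of 3,4-dichlorophenyl on a carbonyl carbon. For the measured compounds named here, no pair of measured compounds shows the outcome of such a change, so its size cannot be read from the data. Because compound 1 gives 89%, the expected step is a number 3 percentage points higher from compound 1 to compound 3 (within the scatter), none beyond the scatter. For compound 3 the estimated value in this assay is 92%, with a range from 80% to 102%.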

Compound 3, a percentage reported as activity, at one concentration (the size of the read-out at that concentration, not a potency): 94%
The estimate for compound 3 lay 2 percentage points below the measured number, and the stated range covers the measured number.
By their numbers in this assay, from the lowest: compounds 1, 3 and 2 (each within the scatter of the next).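

The exchange of 3,4-dichlorophenyl for 3,4-dimethoxyphenyl on a carbonyl carbon gives a number 5 percentage points higher from compound 1 to compound 3 (within the scatter) in this assay. Among the compounds shown here, this is the first pair that differs in one place, and it shows that, at the one concentration tested, a group with hydrogen-bond acceptors and a group with none cannot be told apart at this position. No evidence on the reason for this outcome is at hand.

The compounds shown leave open whether a carboxylic acid or a nitrile on the aromatic ring, or a longer chain in place of that ring, would give a stronger effect at this position. They also leave open whether compound 1 and compound 3 would differ at any other concentration.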